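Moving the chlorines on a dichlorophenyl ketone

The source may report more compounds than this note shows. Statements on the series, on what has been measured and on what is new or still open speak of the compounds shown alone.

Measured in a functional assay on SW-620 cells (Homo sapiens) for cytotoxicity, read by MTT assay, with a stated time of 72 h; on this read-out lower numbers stand for stronger inhibition and higher numbers for weaker inhibition:
- compound 1 `COc1cccc(/C=C2\CCC/C(=C\c3ccc(OC)c(OC)c3)C2=O)c1`: 3700 nM
- compound 2 `COc1ccc(/C=C2\CCC/C(=C\c3ccc(Cl)cc3Cl)C2=O)cc1OC`: 10300 nM

Compound 2, at 10300 nM, holds the higher of the measured numbers in this assay, and so the weaker inhibition. Its nearest neighbour is compound 1, at 3700 nM. Compound 3 `COc1ccc(/C=C2\CCC/C(=C\c3cc(Cl)cc(Cl)c3)C2=O)cc1OC` has not yet been measured. It keeps the rest of compound 2 and differs at one place: 3,5-dichlorophenyl in place of 2,4-dichlorophenyl on a double-bonded chain carbon bound to a double-bonded ring carbon. There, 3,5-dichlorophenyl stands in place of 2,4-dichlorophenyl, on a double-bonded chain carbon bound to a double-bonded ring carbon.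

Among the measured compounds shown here, only one measured step bears on this place: a 2.8-fold higher number from compound 1 to compound 2 (0.44 log units; beyond the scatter). That modest step exchanged 3-methoxyphenyl for 2,4-dichlorophenyl, so it compares different groups and does not show what a shift of the chlorine atoms does. The data therefore give no firm direction, and the change is expected to stay small. The expected step is a 1.3-fold lower number from compound 2 to compound 3 (0.11 log units; within the scatter), which would not clearly separate the pair. For compound 3 the estimated value is 8000 nM, with an expected range of 3000 nM to 20000 nM.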

Compound 3, half-maximal inhibitory concentration: 2500 nM
For compound 3 the middle estimate is 3.2-fold (0.51 log units) above the measured one; the whole stated range lies above it.
By their numbers in this assay, from the lowest: compounds 3 and 1 (each within the scatter of the next); then compound 2.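

In this assay, the new result shows that this place responds to how the chlorine atoms are arranged and not only to which kind of group stands there: with the same atoms joined differently, 3,5-dichlorophenyl in place of 2,4-dichlorophenyl gives a 4.1-fold lower number from compound 2 to compound 3 (0.61 log units; beyond the scatter). The earlier step had exchanged 3-methoxyphenyl for 2,4-dichlorophenyl, so it could not separate the presence of the chlorine atoms from their arrangement; the comparison now available gives a 1.5-fold lower number from compound 1 to compound 3 (0.17 log units; within the scatter), which leaves that pair indistinguishable and shows that a dichlorophenyl group at this place does not by itself go with the higher number seen for compound 2. Nothing measured here explains why the two arrangements of chlorine differ.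

The compounds shown cover only two arrangements of the chlorine atoms, so it stays open whether a single chlorine, a trifluoromethyl group or a nitrile in place of the dichlorophenyl groups would fall nearer compound 2 or compound 3. On these data alone, all of this also rests on one assay in one cell line, so whether the gap between compound 2 and compound 3 holds elsewhere remains unknown.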